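Chlorophenyl placement on the urea: notes on four compounds

A few compounds are considered here, and "the series" means these few. Any claim that something is new, unique, unknown or untested is made for them only; others in the source may bear on it.

Measured compounds:
Compound 1 `CCN(CC)CCNc1nc(-c2ccc(NC(=O)Nc3ccc(Cl)cc3)cc2)nc2c(Cl)c(Cl)sc12` gives 320 nM in a functional assay on NCI-H460 cells (Homo sapiens) for cytotoxicity, read by MTT assay, with a stated time of 72 h; a lower number here means a stronger inhibitor, a higher number a weaker inhibitor.
Compound 2 `CCN(CC)CCNc1nc(-c2ccc(NC(=O)Nc3ccc(Cl)cc3)cc2)nc2ccsc12` gives 190 nM in this assay.
Compound 3 `CCN(CC)CCNc1nc(-c2ccc(NC(=O)Nc3ccccc3Cl)cc2)nc2c(Cl)c(Cl)sc12` gives 460 nM in this assay.

Compound 4 `CCN(CC)CCNc1nc(-c2ccc(NC(=O)Nc3ccccc3Cl)cc2)nc2ccsc12` has not yet been measured in this assay.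

The four compounds fall into two pairs. Compound 1 and compound 3 share one core, compound 2 and compound 4 share another; the difference between the two cores is not broken down here. Within each pair a single change is made on the urea. From compound 1 to compound 3 the change is 2-chlorophenyl in place of 4-chlorophenyl on an amide-type nitrogen, and it gave a 1.4-fold higher number from compound 1 to compound 3 (0.16 log units; within the scatter). From compound 2 to compound 4 the change is 2-chlorophenyl in place of 4-chlorophenyl on an amide-type nitrogen, at the same place, with the same neighbours around it, so it is the same change carried onto the second core.

Among the measured values, compound 2 and compound 1 lie within the scatter of each other, while compound 3 lies beyond the scatter of compound 2.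

Among the measured compounds shown here, the only guide to the step from compound 2 to compound 4 is the one precedent, which stayed within the scatter. On that basis the step from compound 2 to compound 4 is expected to be a 1.4-fold higher number from compound 2 to compound 4 (0.15 log units; within the scatter), of the same order as a 1.4-fold higher number from compound 1 to compound 3 (0.16 log units; within the scatter). Compound 4 is therefore estimated at 270 nM, with a likely range from 120 nM to 600 nM, the range kept wide because the precedent for this change rests on one pair only.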

Compound 4, half-maximal inhibitory concentration: 320 nM
Compound 4: the middle estimate sits 1.2-fold (0.07 log units) below what was measured, within the range that was stated.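

In this assay, 2-chlorophenyl in place of 4-chlorophenyl on the urea nitrogen, carried onto the second core, gave a 1.7-fold higher number from compound 2 to compound 4 (0.23 log units; within the scatter). Set beside the step on the first core, the change reads the same on both cores: the same change on two cores in this assay, a 1.4-fold higher number (0.16 log units; within the scatter) from compound 1 to compound 3 and a 1.7-fold higher number (0.23 log units; within the scatter) from compound 2 to compound 4, 1.2-fold (0.07 log units) apart, within the scatter of two such steps

For these two cores, then, the change carries over without a detectable dependence on the core, and on neither core does it give a step beyond the scatter. This does not show that the two chlorophenyl groups are equivalent, nor that either is preferred, since steps within the scatter can settle neither point, and two pairs make no rule for any further core.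

Open, going by these compounds, is how the urea would read with a phenyl group carrying no chlorine, or with a methoxy group, an amine or a carboxylic acid in place of the chlorine. Also open, on these data alone, is whether the agreement between the two cores would survive a longer chain in place of the diethylaminoethyl chain that all four compounds share.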